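This account rests on a few compounds, and the source may have more. Where it says the series, first, only, none or still open, it means among the compounds named here.

Among the measured compounds shown here, compound 2 `CCCCC(=O)c1c(C)nn(CCCN2CCN(c3ccc(C)cc3)CC2)c(=O)c1N` has the lowest of the two numbers so far: in a functional assay on the whole organism (Abdomen, strain Swiss) for inhibition, with Mus musculus as the target, with stated times of 30 min, 10 min and 5 min, at a dose of 10 mg/kg by the oral route (on this read-out higher numbers stand for a stronger effect at the one dose given and lower numbers for a weaker effect), compound 2 gives 8%, whereas compound 1 `CC(=O)c1c(C)nn(CCCN2CCN(c3ccc(C)cc3)CC2)c(=O)c1N` gives 19%. For the measured compounds named here, the one measured step, a number 11 percentage points lower from compound 1 to compound 2 (beyond the scatter), came with the propyl in place of hydrogen on a saturated chain carbon bound to a carbonyl carbon. Compound 3 `C/C=C/c1c(C)nn(CCCN2CCN(c3ccc(C)cc3)CC2)c(=O)c1N` carries prop-1-en-1-yl in place of butylcarbonyl on an aromatic carbon. Going by the values given here, no measured step removes the carbonyl, so that step bears on the change only loosely; a size within the scatter is expected, a number 4 percentage points higher from compound 2 to compound 3 (within the scatter). For compound 3 the expected value is 12%, within 0% to 28%.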

Compound 3, a percentage reported as inhibition, in the whole organism at one dose (the size of the read-out at that dose, not a potency): 0%
Estimate against measurement, compound 3: 12 percentage points above; low and high end bracket the measured number.
By their numbers in this assay, from the lowest: compounds 3 and 2 (each within the scatter of the next); then compound 1.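

In this assay, prop-1-en-1-yl in place of butylcarbonyl gives a number 8 percentage points lower from compound 2 to compound 3 (within the scatter), so at this position the removal of the carbonyl cannot be separated from the scatter when the starting point is compound 2. Prop-1-en-1-yl in place of acetyl gives a number 19 percentage points lower from compound 1 to compound 3 (beyond the scatter), so the acetyl of compound 1 stands clear of this replacement. Nothing available explains either step.

Still open, on these data alone, is how a carboxylic acid or a primary amide would read at this position, and whether any group there exceeds compound 1.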